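The source may hold more compounds than are shown below. What is called first, only, known or untested is meant among the compounds shown, and "the series" means these compounds.

Measured compounds:
compound 1 `O=C(NCc1ccc(S(=O)(=O)c2ccccc2)cc1)c1ccc2ccncc2c1`, which gives 3.3%
compound 2 `O=C(NCc1ccc(S(=O)(=O)c2ccccc2)cc1)c1nc2cnccc2[nH]1`, which gives 7.3%
compound 3 `O=C(NCc1ccc(S(=O)(=O)c2cccc(C(F)(F)F)c2)cc1)c1cc2cnccc2[nH]1`, which gives 49%

All three were tested in an ADME assay on microsomes from liver (Mus musculus) for metabolic stability, read by LC-MS, with a stated time of 30 min, tested at 1 uM; a higher number here means that more of the compound is left, a lower number that less of the compound is left. Among the three numbers, compound 2 holds the second highest. The nearest to it is compound 1, whose number is lower by an amount that stays within the usual scatter of this assay, so the two cannot be told apart. The furthest is compound 3, whose number lies higher by an amount well beyond the scatter. No pair of these compounds differs in only one place, so no single step between measured compounds can be read off.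

Compound 4 `O=C(NCc1ccc(S(=O)(=O)c2ccccc2)cc1)c1nc2ccncc2s1` has not yet been measured in this assay. Compared with compound 2, it carries the following change: a group of 9 heavy atoms (6 carbon, 2 nitrogen, 1 sulfur; one five-membered aromatic ring with 2 hetero atoms, one six-membered aromatic ring with 1 hetero atom) in place of a group of 9 heavy atoms (6 carbon, 3 nitrogen; one five-membered aromatic ring with 2 hetero atoms, one six-membered aromatic ring with 1 hetero atom), on a carbonyl carbon. Among the compounds with values here, the measured compounds offer no step of this kind: compound 1 and compound 3 each differ from compound 2 in more than one place. Within the data shown here, with no comparable step available, the account expects a step of small size from compound 2 to compound 4, possibly upward, but not clearly beyond the scatter. The estimated step is a number 2.7 percentage points higher from compound 2 to compound 4 (within the scatter). Compound 4 is therefore expected to give 10% in this assay, with a range from 2% to 30%.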

Compound 4, percent of the compound remaining: 26%
Beside the measured number, compound 4's estimate is 16 percentage points below it; measured number inside the range.
By their numbers in this assay, from the lowest: compounds 1 and 2 (each within the scatter of the next); then compound 4; then compound 3.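

In this assay, within the data shown here, the exchange on the carbonyl carbon gives a number 18.7 percentage points higher from compound 2 to compound 4 (beyond the scatter) and is the first change in this set that can be read at one place, since the earlier compounds each differ in more than one. The two groups have the same count of heavy atoms and the same ring sizes: the one that leaves has 3 nitrogen atoms, 1 hydrogen-bond donor and 2 hydrogen-bond acceptors, while the one that enters has 2 nitrogen atoms, 1 sulfur atom, 0 hydrogen-bond donors and 3 hydrogen-bond acceptors, so this place responds to a swap that leaves the size of the group unchanged. No measurement shown here bears on why the number moves.

As far as these compounds go, whether the rise follows the sulfur atom or the loss of the donor stays open, and a methyl group on the ring nitrogen or an oxygen atom in place of the sulfur would bear on that question. Also open, from the compounds shown here alone, is how the same exchange would read with the trifluoromethyl group that compound 3 carries on its sulfonyl-bound phenyl ring.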